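Trifluoromethyl in place of methyl: notes on the series

The source may report more compounds than this note shows. Statements on the series, on what has been measured and on what is new or still open speak of the compounds shown alone.

In a functional assay on RAW264.7 cells (Mus musculus), with a stated time of 3 days (on this read-out lower numbers stand for stronger inhibition and higher numbers for weaker inhibition), compound 1 `COc1cnc(-c2ccccn2)nc1N(C)C1CCCC1` gives 180 nM. On the same read-out compound 2 `COc1cnc(-c2ccccn2)nc1NCc1ccccc1C` gives 220 nM. Within the data shown here, these two numbers lie within the scatter of each other, so compound 2 does not stand apart from the only other measured member of the series, even though the two compounds carry different substituents on the shared core.

The next compound is compound 3 `COc1cnc(-c2ccccn2)nc1NCc1ccccc1C(F)(F)F`, which differs from compound 2 by trifluoromethyl in place of methyl on an aromatic carbon. The change is trifluoromethyl in place of methyl on an aromatic carbon, ortho to a large group. Among the measured compounds shown here, no measured pair tests a change at this place, so the data give no direct guide to the size or direction of the step. The expectation therefore rests on compound 2 at 220 nM alone, and no shift beyond the scatter is expected in this assay. The estimated step is a 1.1-fold higher number from compound 2 to compound 3 (0.06 log units; within the scatter). For compound 3 the expected value is 250 nM, with an estimated range of 90 nM to 700 nM.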

Compound 3, half-maximal inhibitory concentration: 230 nM
Estimate against measurement, compound 3: 1.1-fold (0.04 log units) above; the measured number falls inside the stated range.
By their numbers in this assay, from the lowest: compounds 1, 2 and 3 (each within the scatter of the next).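

In this assay, trifluoromethyl in place of methyl on an aromatic carbon, ortho to a large group, gives a 1.0-fold higher number from compound 2 to compound 3 (0.02 log units; within the scatter), and this is the only pair shown that tests a change at this place. Methyl, with 1 heavy atom, and trifluoromethyl, with 4 heavy atoms including 3 fluorine, are therefore not told apart at this place on this read-out, which the earlier pair of compounds, differing in more than one place, could not show. No measurement shown here bears on why the two groups read alike.

Still open, going by these compounds, is whether a group of another kind at this place, such as a carboxylic acid, an amine or a longer chain, would give a step beyond the scatter from compound 2. Also open, on these data alone, is whether methyl and trifluoromethyl would stay within the scatter of each other at another carbon of the same six-membered aromatic ring, or on a read-out other than this assay.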